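Aniline swap on compound 1: expected effect on inhibition

The compounds below may be only part of what the source reports. "The series", "measured", "known", "first", "only" and "open" are said of these compounds alone.

In a functional assay on HCC827 cells (Homo sapiens) for inhibition, read by MTT assay, with a stated time of 48 h, tested at 10 uM (a higher number here means more inhibition at the concentration tested (going by the name of the read-out), a lower number less inhibition), compound 1 `COc1cc(NC(=O)Nc2cc(Nc3ccc(C(C)(C)C)cc3)ncn2)cc(OC)c1` gives 32.7%, the lowest of the three numbers in hand. Compound 3 `COc1cc(Nc2cc(NC(=O)Nc3c(Cl)cccc3Cl)ncn2)cc(OC)c1` gives 73.7% and compound 2 `Cc1ccc(Nc2cc(NC(=O)Nc3c(Cl)cccc3Cl)ncn2)cc1C` gives 84.3%, both beyond the scatter above compound 1. Going by the values given here, no single-change step between measured compounds is available, so the change leading to compound 4 `COc1cc(NC(=O)Nc2cc(Nc3cc(I)ccc3OC)ncn2)cc(OC)c1` has no precedent in this set: 5-iodo-2-methoxyphenyl in place of 4-(tert-butyl)phenyl on a nitrogen on an aromatic ring. The rest of compound 1 is kept. Because compound 1 gives 32.7%, the step of a number 12.3 percentage points higher from compound 1 to compound 4 (beyond the scatter) is expected to be small and upward, possibly not beyond the scatter. For compound 4 the estimate in this assay is 45% with a range of 20% to 70%.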

Compound 4, a percentage reported as inhibition, at one concentration (the size of the read-out at that concentration, not a potency): 71%
Beside the measured number, compound 4's estimate is 26 percentage points below it, outside the stated range (above it).
By their numbers in this assay, from the lowest: compound 1; then compounds 4 and 3 (each within the scatter of the next); then compound 2.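

The group on a nitrogen on an aromatic ring is a position that responds: with the rest of compound 1 kept, 5-iodo-2-methoxyphenyl in place of 4-(tert-butyl)phenyl gives, in this assay, a large step, a number 38.3 percentage points higher from compound 1 to compound 4 (beyond the scatter). Going by these compounds alone, this is the first single-change step. Nothing measured ties this step to any property of either group.

On these data alone, the new group differs in both iodine and methoxy, so which of them carries the step stays open. As far as these compounds go, how a plain phenyl or a carboxylic acid on that ring would read also stays open.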